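From Hydroxy to a Boron-Bearing Group

The source may report more compounds than this note shows. Statements on the series, on what has been measured and on what is new or still open speak of the compounds shown alone.

Compound 1 `COc1ccc(/C=C/C(=O)c2ccccc2-c2ccc(F)cc2)cc1` gives 210 nM
Compound 2 `COc1ccc(/C=C/C(=O)c2ccccc2-c2ccc(F)cc2)cc1O` gives 430 nM

Both values come from a functional assay on A549 cells (Homo sapiens) for antiproliferative activity, read by sulforhodamine B assay, with a stated time of 48 h (on this read-out lower numbers stand for stronger inhibition and higher numbers for weaker inhibition), and compound 2 holds the higher number of the two, so it is the weaker inhibitor of this pair. Compound 3 `COc1ccc(/C=C/C(=O)c2ccccc2-c2ccc(F)cc2)cc1B(O)O` is compound 2 with one change: a group of 3 heavy atoms (1 boron, 2 oxygen; no ring) in place of one oxygen atom, on an aromatic carbon on an aromatic carbon, ortho to a methoxy group. Among the compounds with values here, only one measured step bears on this carbon, where hydroxy took the place of hydrogen: a 2.0-fold higher number from compound 1 to compound 2 (0.31 log units; beyond the scatter). That step is modest, and it says nothing direct about the new group. No step beyond the scatter is therefore expected in this assay, and neither direction is favoured. For compound 3 the expected value is 400 nM, with an estimated range from 120 nM to 1400 nM. The expected change is a 1.1-fold lower number from compound 2 to compound 3 (0.03 log units; within the scatter).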

Compound 3, half-maximal inhibitory concentration: 74 nM
Beside the measured number, compound 3's estimate is 5.4-fold (0.73 log units) above it; measured number outside the range, below it.
By their numbers in this assay, from the lowest: compound 3; then compound 1; then compound 2.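

The carbon ortho to a methoxy group is not simply a place where a new substituent costs activity: in this assay, the boron-bearing group in place of hydroxy gives a 5.8-fold lower number from compound 2 to compound 3 (0.76 log units; beyond the scatter) and marks a clear gain in inhibition. Set against plain hydrogen, the same group gives a 2.8-fold lower number from compound 1 to compound 3 (0.45 log units; beyond the scatter) and so also beats the unsubstituted compound, which means that a substituent here can move the number either way, up with hydroxy and down with the boron-bearing group. Nothing available explains why these two groups part ways.

Going by these compounds, whether the gain is special to boron stays open, since an amine, a carboxylic acid or a simple methyl on this carbon would test how other groups compare. It is also unknown whether the boron-bearing group would do the same elsewhere on the shared core.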